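The compounds below may be only part of what the source reports. "The series", "measured", "known", "first", "only" and "open" are said of these compounds alone.

Working notes on the series, read in a functional assay on the whole organism (strain albino) with Rattus norvegicus as the target, read by paw edema, with stated times of 1 h and 4 h, at a dose of 50 mg/kg by the oral route; on this read-out lower numbers stand for a weaker effect and higher numbers for a stronger effect at the one dose given.

Compound 1 `COc1ccc(C2CC(c3ccc(NC(=O)c4cc(Cl)ccc4OC)cc3)=NN2c2ccccc2)cc1` carries a methoxy on the pendant phenyl and a phenyl on the ring nitrogen; in this assay compound 1 gives 98%. Compound 2 `COc1ccc(Cl)cc1C(=O)Nc1ccc(C2=NN(c3ccccc3)C(c3ccc([N+](=O)[O-])cc3)C2)cc1` carries a nitro in place of that methoxy, and compound 2 gives 94.1%; the change reads a number 3.9 percentage points lower from compound 1 to compound 2 (within the scatter). Compound 3 `COc1ccc(C2CC(c3ccc(NC(=O)c4cc(Cl)ccc4OC)cc3)=NN2)cc1` has hydrogen in place of the phenyl on the ring nitrogen, and compound 3 gives 89%; the change reads a number 9 percentage points lower from compound 1 to compound 3 (within the scatter). Compound 3 thus stands at the bottom of the three numbers shown, with compound 2 nearest and compound 1 furthest, yet both gaps lie within the usual scatter.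

Compound 4 `COc1ccc(Cl)cc1C(=O)Nc1ccc(C2=NNC(c3ccc([N+](=O)[O-])cc3)C2)cc1` differs from compound 3 in one place: nitro in place of methoxy on an aromatic carbon. Going by the values given here, the only measured step that bears on this change is the one from compound 1 to compound 2, where the same exchange was made on the phenyl-bearing core and gave a number 3.9 percentage points lower from compound 1 to compound 2 (within the scatter). On that basis, compound 4 is expected to show no step beyond the scatter, and the expected step is a number 4 percentage points lower from compound 3 to compound 4 (within the scatter). The estimate for compound 4 is therefore 85%, with a range from 75% to 95%.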

Compound 4, a percentage reported as activity, at one dose (the size of the read-out at that dose, not a potency): 95.3%
Compound 4: the middle estimate sits 10.3 percentage points below what was measured, outside the stated range (above it).
By their numbers in this assay, from the lowest: compounds 3, 2, 4 and 1 (each within the scatter of the next).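

The exchange of 4-methoxyphenyl to 4-nitrophenyl can now be read on two cores in this assay, and on the core with hydrogen on the ring nitrogen it gives a number 6.3 percentage points higher from compound 3 to compound 4 (within the scatter), so the two steps carry opposite signs but cannot be told apart: the same change on two cores in this assay, a number 3.9 percentage points lower (within the scatter) from compound 1 to compound 2 and a number 6.3 percentage points higher (within the scatter) from compound 3 to compound 4, 10.2 percentage points apart, within the scatter of two such steps. Hydrogen in place of phenyl on the ring nitrogen can likewise now be read with nitro as well as with methoxy, where it gives a number 1.2 percentage points higher from compound 2 to compound 4 (within the scatter), and again the two steps cannot be told apart: the same change on two cores in this assay, a number 9 percentage points lower (within the scatter) from compound 1 to compound 3 and a number 1.2 percentage points higher (within the scatter) from compound 2 to compound 4, 10.2 percentage points apart, within the scatter of two such steps. Neither change therefore moves the read-out beyond the scatter on either core, and the position on the aromatic ring para to a large group shows no dependence on methoxy or nitro in these four compounds.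

On these data alone, whether an amine or a carboxylic acid at that position, or a longer chain such as butoxy, would shift the number beyond the scatter remains open, as does the effect of an acetyl group on the ring nitrogen. With a single dose, the read-out also leaves the relative potency of these four compounds open.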